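The source may report more compounds than this note shows. Statements on the series, on what has been measured and on what is new or still open speak of the compounds shown alone.

Measured compounds:
Compound 1, `COc1cc2c(Oc3ccc(NC(=O)c4nn(-c5ccccc5C(F)(F)F)c(=O)cc4C)cc3F)ccnc2cc1OCCCN1CCC(C)CC1`: 160 nM
Compound 2, `COc1cc2c(Oc3ccc(NC(=O)c4nn(-c5ccccc5OC(F)(F)F)c(=O)cc4C)cc3F)ccnc2cc1OCCCN1CCCCC1`: 120 nM

Both compounds were tested in a functional assay on A549 cells (Homo sapiens) for inhibition, read by MTT assay, with a stated time of 72 h; a higher number here means a weaker inhibitor, a lower number a stronger inhibitor. In this assay compound 1 gives 160 nM and compound 2 gives 120 nM. Compound 2 has the lower of the two numbers, but the gap to compound 1 lies within the scatter of repeated measurements, so the two cannot be told apart on these data.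

Compound 3, `COc1cc2c(Oc3ccc(NC(=O)c4nn(-c5ccccc5OC(F)(F)F)c(=O)cc4C)cc3F)ccnc2cc1OCCCN1CCC(C)CC1`, has not yet been measured. It differs from compound 2 in a single place: methyl in place of hydrogen on a saturated ring carbon. Compound 2 and compound 3 therefore differ only by a methyl in place of hydrogen on a saturated ring carbon, far from the amide and the shared core.

Within the data shown here, no pair of measured compounds isolates exactly this change, so no measured step tells its size. Among the measured compounds shown here, the only guide is that compound 1 and compound 2, which differ at two places, sit within the scatter of each other. On that basis the step from compound 2 to compound 3 is expected to be small, a 1.2-fold higher number from compound 2 to compound 3 (0.07 log units; within the scatter), with no clear direction beyond the scatter. Compound 3 is thus estimated to give about 140 nM in this assay, most likely between 60 nM and 350 nM.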

Compound 3, half-maximal inhibitory concentration: 90 nM
The estimate for compound 3 lay 1.6-fold (0.19 log units) above the measured number, within the range that was stated.
By their numbers in this assay, from the lowest: compounds 3, 2 and 1 (each within the scatter of the next).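

Compound 1 and compound 2 differ at two places at once, so neither change could be read alone; compound 3 pulls them apart. In this assay going from piperidin-1-yl to 4-methylpiperidin-1-yl gives a 1.3-fold lower number from compound 2 to compound 3 (0.12 log units; within the scatter) and so shows that a methyl on this saturated ring carbon, three ring bonds from the ring nitrogen, makes no difference that can be told from the scatter. The other change, trifluoromethoxy in place of trifluoromethyl on an aromatic carbon, gives a 1.8-fold lower number from compound 1 to compound 3 (0.25 log units; within the scatter) and can likewise not be told from the scatter, and no further data bear on why either step is this small.

On these data alone, both changes are small, and a single methyl says little about what this ring carbon would accept, so it remains open whether a larger or different group there, such as a phenyl, a hydroxyl or a carboxylic acid, would move the number beyond the scatter. Equally open, as far as these compounds go, is whether replacing the whole ring with morpholin-4-yl, or putting a chlorine or a methoxy in place of the trifluoromethoxy, would do so.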